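Amine swap on the alkoxy chain of compound 2

The source may report more compounds than this note shows. Statements on the series, on what has been measured and on what is new or still open speak of the compounds shown alone.

For the measured compounds named here, compound 2 `CCN(CC)CCCOc1ccc2cc(NC(=O)c3ccc(O)c(CC=C(C)C)c3)c(=O)oc2c1C` gives 4900 nM in a functional assay on SK-BR-3 cells (Homo sapiens) for antiproliferative activity (a higher number here means a weaker inhibitor, a lower number a stronger inhibitor), the higher of the two numbers measured so far. Going by the values given here, compound 1 `CC(=O)Oc1ccc(C(=O)Nc2cc3ccc(OCCC4CCCCN4)c(C)c3oc2=O)cc1CC=C(C)C` gives 640 nM in this assay; no step between these two is computed, so only their two values are set side by side. Compound 3 `COC(=O)CNCCCOc1ccc2cc(NC(=O)c3ccc(O)c(CC=C(C)C)c3)c(=O)oc2c1C` carries ((methoxycarbonyl)methyl)amino in place of diethylamino on a saturated chain carbon, three bonds along the chain from an oxygen on an aromatic ring. Among the compounds with values here, no measured pair shares this change, so its effect is unknown. The step of a 1.0-fold higher number from compound 2 to compound 3 (0.01 log units; within the scatter) is expected to stay within the scatter, with no clear direction. Compound 3 is therefore estimated at 5000 nM, with a range from 1500 nM to 16000 nM.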

Compound 3, half-maximal inhibitory concentration: 1060 nM
Compound 3: middle estimate off by 4.7-fold (0.67 log units), on the high side; measured number below the stated range.
By their numbers in this assay, from the lowest: compounds 1 and 3 (each within the scatter of the next); then compound 2.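

At the amine end of the 3-(diethylamino)propyl chain, the choice of group registers in this assay: ((methoxycarbonyl)methyl)amino in place of diethylamino gives a 4.6-fold lower number from compound 2 to compound 3 (0.66 log units; beyond the scatter). This position therefore tolerates the larger group, which also carries a hydrogen-bond donor that diethylamino lacks. No available data bear on the reason for this step.

On these data alone, it remains open whether the lower number goes with the amine hydrogen or with the methyl ester. A carboxylic acid or a plain ethylamino group at the chain end would separate the two.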